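This account rests on a few compounds, and the source may have more. Where it says the series, first, only, none or still open, it means among the compounds named here.

Working notes on the series, read in a functional assay on PC-3 cells (Homo sapiens) for cytotoxicity, read by MTT assay, with a stated time of 72 h; a higher number here means a weaker inhibitor, a lower number a stronger inhibitor. Compound 1 (`COc1cc(/C=C/C(=O)Nc2cc3c(Nc4ccc(F)c(Cl)c4)ncnc3cc2O[C@H]2CCOC2)cc(OC)c1OC`) gives 20500 nM, compound 2 (`O=C(/C=C/c1cc(Br)c(O)c(Br)c1)Nc1cc2c(Nc3ccc(F)c(Cl)c3)ncnc2cc1O[C@H]1CCOC1`) gives 25500 nM, and compound 3 (`COc1ccc(/C=C/C(=O)Nc2cc3c(Nc4ccc(F)c(Cl)c4)ncnc3cc2O[C@H]2CCOC2)c(OC)c1OC`) gives 7670 nM, the lowest of the three numbers. Compound 4 (`COc1ccc(/C=C/C(=O)Nc2cc3c(Nc4ccc(F)c(Cl)c4)ncnc3cc2O[C@H]2CCOC2)cc1`) carries 4-methoxyphenyl in place of 2,3,4-trimethoxyphenyl on a double-bonded chain carbon bound to a double-bonded chain carbon. The steps that end on the 2,3,4-trimethoxyphenyl group are a 2.7-fold lower number from compound 1 to compound 3 (0.43 log units; beyond the scatter) and a 3.3-fold lower number from compound 2 to compound 3 (0.52 log units; beyond the scatter), both modest and beyond the scatter, while a 1.2-fold higher number from compound 1 to compound 2 (0.09 log units; within the scatter) lies within it. Within the data shown here, no measured step tests 4-methoxyphenyl itself, so the expectation is loose. A modest move to a higher number is expected, with an estimated 2.1-fold higher number from compound 3 to compound 4 (0.32 log units; beyond the scatter). Compound 4 is estimated at 16000 nM, with an expected range of 6000 nM to 40000 nM.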

Compound 4, half-maximal inhibitory concentration: 2240 nM
For compound 4 the middle estimate is 7.1-fold (0.85 log units) above the measured one; the whole stated range lies above it.
By their numbers in this assay, from the lowest: compound 4; then compound 3; then compounds 1 and 2 (each within the scatter of the next).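

In this assay, 4-methoxyphenyl on the double-bonded chain carbon gives a 3.4-fold lower number from compound 3 to compound 4 (0.53 log units; beyond the scatter) against 2,3,4-trimethoxyphenyl, with a 9.2-fold lower number from compound 1 to compound 4 (0.96 log units; beyond the scatter) against 3,4,5-trimethoxyphenyl and an 11-fold lower number from compound 2 to compound 4 (1.06 log units; beyond the scatter) against 3,5-dibromo-4-hydroxyphenyl. At this position, the smallest group of the four, with the fewest hydrogen-bond acceptors, now gives the lowest number, so a fuller substitution pattern is not needed for the lowest number in this set. No measured evidence accounts for this change. Among these compounds, whether the single methoxy group matters at all remains open, since an unsubstituted phenyl or a 4-(dimethylamino)phenyl on the same chain carbon would separate its contribution.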